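Cyclohexylamino to (naphthalen-1-yl)methoxy: notes on compound 4

The source may report more compounds than this note shows. Statements on the series, on what has been measured and on what is new or still open speak of the compounds shown alone.

- compound 1 `O=C(N[C@@H](CCCCCCSSc1ccccn1)C(=O)NC1CCCCC1)OCc1ccccc1`: 19600 nM
- compound 2 `O=C(N[C@@H](CCCCCCSSc1ccccn1)C(=O)OCc1cccc([N+](=O)[O-])c1)OCc1ccccc1`: 15200 nM
- compound 3 `O=C(N[C@@H](CCCCCCSSc1ccccn1)C(=O)OCc1ccc2ccccc2c1)OCc1ccccc1`: 14800 nM

All three compounds were measured in a functional assay on MCF7 cells (Homo sapiens) for antiproliferative activity, read by MTT assay, with a stated time of 48 h; a lower number here means a stronger inhibitor, a higher number a weaker inhibitor. Compound 1 does not separate from the other two: the record shows a 1.3-fold lower number from compound 1 to compound 2 (0.11 log units; within the scatter) and a 1.3-fold lower number from compound 1 to compound 3 (0.12 log units; within the scatter). The remaining comparison, a 1.0-fold lower number from compound 2 to compound 3 (0.01 log units; within the scatter), also stays within the scatter.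

Compound 4 `O=C(N[C@@H](CCCCCCSSc1ccccn1)C(=O)OCc1cccc2ccccc12)OCc1ccccc1` has not yet been measured. It carries (naphthalen-1-yl)methoxy in place of cyclohexylamino on a carbonyl carbon, and the counted difference is (naphthalen-1-yl)methoxy in place of cyclohexylamino on a carbonyl carbon.

The closest evidence is compound 3, which has (naphthalen-2-yl)methoxy on that carbonyl carbon and gives 14800 nM. Compound 2, with (3-nitrobenzyl)oxy there, gives 15200 nM. Neither replacement of cyclohexylamino moved the number beyond the scatter, and exchanging one for the other did not either. Among the compounds with values here, no measured compound yet carries the (naphthalen-1-yl)methoxy group itself, so the expectation is borrowed from these neighbours.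

No step beyond the scatter is expected, and the estimated change is a 1.3-fold lower number from compound 1 to compound 4 (0.12 log units; within the scatter). For compound 4 the estimated value is 15000 nM, with an expected range of 9000 nM to 24000 nM.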

Compound 4, half-maximal inhibitory concentration: 15300 nM
Compound 4: middle estimate off by 1.0-fold (0.01 log units), on the low side, and the stated range covers the measured number.
By their numbers in this assay, from the lowest: compounds 3, 2, 4 and 1 (each within the scatter of the next).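

In this assay, a third replacement of cyclohexylamino on this carbonyl carbon gives a 1.3-fold lower number from compound 1 to compound 4 (0.11 log units; within the scatter) and so adds (naphthalen-1-yl)methoxy to the groups that do not separate from it, even though the amide hydrogen counted as a donor in cyclohexylamino is absent and two aromatic rings enter. The series now also holds a direct exchange of naphthalen-2-yl for naphthalen-1-yl on the saturated chain carbon, which gives a 1.0-fold higher number from compound 3 to compound 4 (0.01 log units; within the scatter) and shows no separation between these two naphthalene groups, while the exchange of 3-nitrophenyl for naphthalen-1-yl gives a 1.0-fold higher number from compound 2 to compound 4 (0.00 log units; within the scatter) and is equally flat. Nothing at hand explains why these different groups give such similar numbers in this cell assay.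

The compounds shown leave open whether any group on this carbonyl carbon can move the number beyond the scatter, since all four carry fairly large groups there and a small one such as a carboxylic acid or a methyl ester is not among them. They also leave open how the number responds to changes elsewhere, for example a shorter chain in the shared core or an amine in place of the benzyl carbamate.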